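From Ethyl to Cyano on the Shared Core

The source may report more compounds than this note shows. Statements on the series, on what has been measured and on what is new or still open speak of the compounds shown alone.

Three compounds have been measured so far:
Compound 1, `Fc1ccccc1Cn1nc(-c2ccco2)c2cccnc21`, gives 9300 nM in a functional assay (aorta) with Oryctolagus cuniculus as the target; on this read-out higher numbers stand for weaker inhibition and lower numbers for stronger inhibition.
Compound 2, `NS(=O)(=O)c1ccc(-c2nn(Cc3ccccc3F)c3ncccc23)o1`, gives 8000 nM in this assay.
Compound 3, `CCc1cnc(-c2nn(Cc3ccccc3F)c3ncccc23)nc1N`, gives 272000 nM in this assay.

Compound 3 stands at the highest number of the three, and its distance from compound 1 and from compound 2 lies beyond the scatter in each case, so it is the least potent of the measured set. Compound 4, `N#Cc1cnc(-c2nn(Cc3ccccc3F)c3ncccc23)nc1N`, is not yet measured. It differs from compound 3 in one place: cyano in place of ethyl on an aromatic carbon.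

Among the measured compounds shown here, only one single-point step has been measured, a 1.2-fold lower number from compound 1 to compound 2 (0.07 log units; within the scatter). That step concerns a different ring and a different group, so it does not speak directly to cyano in place of ethyl. It does show that changing a substituent on an aromatic carbon of the shared core can leave the number essentially unchanged. For the measured compounds named here, with no measured step at the place in question, the expected step is one of no change beyond the scatter, a 1.4-fold lower number from compound 3 to compound 4 (0.13 log units; within the scatter), with a wide range on either side. Compound 4 is therefore estimated at 200000 nM, between 60000 nM and 700000 nM.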

Compound 4, half-maximal inhibitory concentration: 391000 nM
For compound 4 the middle estimate is 2.0-fold (0.29 log units) below the measured one, within the range that was stated.
By their numbers in this assay, from the lowest: compounds 2 and 1 (each within the scatter of the next); then compounds 3 and 4 (each within the scatter of the next).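

In this assay, replacing ethyl with cyano gives a 1.4-fold higher number from compound 3 to compound 4 (0.16 log units; within the scatter), so this pair cannot be told apart at this position, on the six-membered aromatic ring with 2 nitrogen, ortho to an amino group and para to a large group. The earlier compounds shown here said nothing about this place, and the pair now shows that one group of 2 heavy atoms can stand in for another here without a shift beyond the scatter, even though cyano brings a triple bond and a hydrogen-bond acceptor that ethyl lacks. This holds for these two groups only, and no other measurement at hand bears on the reason for the result.

Both groups are small, so the compounds shown leave open whether a larger or very different group at this carbon, such as a carboxylic acid, a dimethylamino group or a longer chain like butyl, would move the number beyond the scatter. They also leave open what plain hydrogen at this carbon would give, and whether the neighbouring amino group matters to the read-out at all.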